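Swapping Fluoro for Methyl on a Shared Amide Core

This account rests on a few compounds, and the source may have more. Where it says the series, first, only, none or still open, it means among the compounds named here.

Of the compounds shown here, two built on one shared core have been tested in a functional assay on MCF7 cells (Homo sapiens) for cytotoxicity, read by MTT assay, with a stated time of 72 h; on this read-out lower numbers stand for stronger inhibition and higher numbers for weaker inhibition. Compound 1 `O=C(Nc1ccc(Oc2ccnc3[nH]ccc23)cc1)c1nccc(-c2ccc(Cl)cc2)n1` gave "not active" (no number reported) in this assay. Compound 2 `O=C(Nc1ccc(Oc2ccnc3[nH]ccc23)cc1)c1cc(-c2ccc(F)cc2)ncn1` gave 15900 nM; this is the only number shown, with compound 1 standing beside it without a single value, so compound 2 is the sole reference point. Compound 3 `Cc1ccc(-c2cc(C(=O)Nc3ccc(Oc4ccnc5[nH]ccc45)cc3)ncn2)cc1` differs from compound 2 by methyl in place of fluoro on an aromatic carbon, or, cut one bond further out, 4-fluorophenyl to 4-methylphenyl. Among the compounds with values here, no measured pair shows what this swap does here. Each group counts one heavy atom and brings no donor or acceptor, and the expected step is a 1.2-fold lower number from compound 2 to compound 3 (0.09 log units; within the scatter), no more than the usual scatter. Compound 3 is therefore estimated at 13000 nM, within a range from 4000 nM to 45000 nM, with a real chance that no number is reported at all.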

Compound 3, half-maximal inhibitory concentration: 1620 nM
Compound 3: the middle estimate sits 8.0-fold (0.90 log units) above what was measured; the whole stated range lies above it.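

In this assay, within the data shown here, changing 4-fluorophenyl to 4-methylphenyl gives a 9.8-fold lower number from compound 2 to compound 3 (0.99 log units; beyond the scatter), the only measured step at this place. This shows that the place, on a six-membered aromatic ring of carbon only and para to a large group, is sensitive: the number shifts beyond the usual scatter even though fluoro and methyl each count one heavy atom and neither brings a hydrogen-bond donor or acceptor. Nothing in the available data explains why this swap changes the number so strongly.

Going by these compounds, a single pair cannot show a trend, so it remains open whether an ethyl group, a methoxy group or an amine at this place would lower the number further or raise it again. On these data alone, it is also open whether methyl would bring a similar step on the core of compound 1, which gives "not active" (no number reported).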